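The source may report more compounds than this note shows. Statements on the series, on what has been measured and on what is new or still open speak of the compounds shown alone.

The account follows compound 1, whose structure is `C=CC(=O)Nc1cccc(Nc2nc(Cl)nc(Nc3ccc(OCCOC)cc3)n2)c1` and whose entry in a functional assay on Ramos cells (Homo sapiens) for antiproliferative activity, read by CCK-8 assay, with a stated time of 24 h (on this read-out lower numbers stand for stronger inhibition and higher numbers for weaker inhibition), reads "not determined" (no result reported), and a close relative of it. In this assay compound 1 thus has no single number: its result was not reported. The same holds for compound 2, whose structure is `C=CC(=O)N1CCc2ccc(Nc3ncnc(Nc4ccc(C(=O)N5CCCCC5)cc4)n3)cc21`, which in this assay also stands as "not determined" (no result reported), without a reported result. Among the compounds with values here, the only compound of the set with a number is compound 3, whose structure is `C=CC(=O)Nc1cccc(Nc2nc(N)nc(Nc3ccc(Oc4ccccc4)cc3)n2)c1`; in this assay compound 3 gives 20000 nM, a weak result on this read-out.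

The step under study leads from compound 1 to compound 4, whose structure is `C=CC(=O)Nc1cccc(Nc2ncnc(Nc3ccc(OCCOC)cc3)n2)c1`. The change is hydrogen in place of chloro on an aromatic carbon of the shared core. Since neither end of this step has a measured value, no measured step size exists. With only compound 3 and its value of 20000 nM as a reference for the series, one expects the step from compound 1 to compound 4 in this assay to be small, most likely within the scatter of repeated measurements, with no clear direction.

Compound 4 is therefore expected to give about 12000 nM in this assay, within a range from 3000 nM to 50000 nM.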

Compound 4, half-maximal inhibitory concentration: 181000 nM
Compound 4: middle estimate off by 15-fold (1.18 log units), on the low side; measured number outside the range, above it.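

No new step can be read: in this assay compound 1 has no single number, so the change from compound 1 to compound 4 has no size. Nothing shown here bears on the result for compound 4. The compounds shown leave open what hydrogen in place of chloro does to this read-out.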